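The source may hold more compounds than are shown below. What is called first, only, known or untested is meant among the compounds shown, and "the series" means these compounds.

Measured so far in a toxicity assay on MT4 cells (Homo sapiens) for cytotoxicity, read by MTT assay; a higher number here means that more compound is tolerated, a lower number that less compound is tolerated:
- compound 1, `Cc1cc(-c2ccccc2)cc(C)c1Oc1cc(N)nc(Nc2ccc(C#N)cc2)n1`: 25600 nM
- compound 2, `Cc1cc(-c2ccccc2F)cc(C)c1Oc1cc(N)nc(Nc2ccc(C#N)cc2)n1`: 29300 nM
- compound 3, `COc1ccc(-c2cc(C)c(Oc3cc(N)nc(Nc4ccc(C#N)cc4)n3)c(C)c2)cc1`: 10700 nM

Compound 2 gives the highest of these three numbers in this assay. Its nearest neighbour is compound 1, with a 1.1-fold higher number from compound 1 to compound 2 (0.06 log units; within the scatter), a step that lies within the scatter, so the two cannot be told apart. The furthest is compound 3, reached by a 2.7-fold lower number from compound 2 to compound 3 (0.44 log units; beyond the scatter), a modest step beyond the scatter; in the same direction, compound 1 to compound 3 shows a 2.4-fold lower number from compound 1 to compound 3 (0.38 log units; beyond the scatter).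

Compound 4, `Cc1cc(-c2ccc(C#N)c(F)c2)cc(C)c1Oc1cc(N)nc(Nc2ccc(C#N)cc2)n1`, has not yet been measured. It differs from compound 2 in one place: 4-cyano-3-fluorophenyl in place of 2-fluorophenyl on an aromatic carbon.

For the measured compounds named here, the steps that bear on this change are the ones that add a group to the same outer ring. A fluorine alone left the number unchanged within the scatter, as a 1.1-fold higher number from compound 1 to compound 2 (0.06 log units; within the scatter) shows. A methoxy group on the same ring lowered it modestly, as in a 2.4-fold lower number from compound 1 to compound 3 (0.38 log units; beyond the scatter). Going by the values given here, the entering 4-cyano-3-fluorophenyl carries both a fluorine and a nitrile, and no measured compound has a nitrile on this ring, so the direction is uncertain; a modest lowering like that of compound 3 is the nearest guide. Compound 4 is therefore expected to give about 18000 nM in this assay, within 8000 nM to 40000 nM, corresponding to an expected step of a 1.6-fold lower number from compound 2 to compound 4 (0.21 log units; within the scatter).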

Compound 4, half-maximal cytotoxic concentration: 5000 nM
For compound 4 the middle estimate is 3.6-fold (0.56 log units) above the measured one, outside the stated range (below it).
By their numbers in this assay, from the lowest: compound 4; then compound 3; then compounds 1 and 2 (each within the scatter of the next).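

In this assay, this position turns out to be able to shift the number further than a fluorine or a methoxy group alone had shown: 4-cyano-3-fluorophenyl in place of 2-fluorophenyl gives a 5.9-fold lower number from compound 2 to compound 4 (0.77 log units; beyond the scatter), and in place of phenyl it gives a 5.1-fold lower number from compound 1 to compound 4 (0.71 log units; beyond the scatter), so less compound is tolerated with the new group. The change also goes past the methoxy compound, with a 2.1-fold lower number from compound 3 to compound 4 (0.33 log units; beyond the scatter), which means that the lowering seen with 4-methoxyphenyl does not mark the low end for this ring, and that a ring carrying a fluorine is not in itself tied to the unchanged number seen with compound 2. Nothing among the available findings gives a reason for this drop.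

The entering group differs from 2-fluorophenyl both in its nitrile and in where its fluorine stands, so the compounds shown do not divide the step between these two features, and a plain 4-cyanophenyl group would be needed to begin separating them. Also open, from the compounds shown here alone, is how an amine or a carboxylic acid on this outer ring would move the number.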